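Adding trifluoromethyl to the amine chain of compound 2

The compounds below may be only part of what the source reports. "The series", "measured", "known", "first", "only" and "open" are said of these compounds alone.

Measured in an ADME assay on liver (Homo sapiens) for metabolic stability, read by LC-MS, using microsomes and NADPH; on this read-out lower numbers stand for a less stable compound and higher numbers for a more stable compound:
- compound 1 `CCCN(Cc1ccc(OCCN2C(=O)CCC2=O)c(C)c1)[C@@H](CC(=O)O)c1ccc(Cl)cc1`: 97%
- compound 2 `CCN(Cc1ccc(OCCN2C(=O)CCC2=O)c(C)c1)C(CC(=O)O)c1ccc(Cl)cc1`: 100%
- compound 3 `Cc1cc(CN(CC2CCCC2)[C@@H](CC(=O)O)c2ccc(Cl)cc2)ccc1OCCN1C(=O)CCC1=O`: 78%

Compound 2 and compound 1 lie within the scatter of each other, while compound 3, at 78%, lies well apart from compound 2, at 100%. The next compound, compound 4 `Cc1cc(CN(CCC(F)(F)F)C(CC(=O)O)c2ccc(Cl)cc2)ccc1OCCN1C(=O)CCC1=O`, has not yet been measured in this assay. It takes compound 2 from ethyl to 3,3,3-trifluoropropyl: trifluoromethyl in place of hydrogen on a saturated chain carbon, two bonds along the chain from an amine nitrogen. Among the compounds with values here, one measured step bears on this change: a number 19 percentage points lower from compound 1 to compound 3 (beyond the scatter), with cyclopentyl in place of ethyl on a saturated chain carbon bound to an amine nitrogen. That single step shows that the number can fall with a change in this region, so a modest fall is expected here too, though the entering group adds no ring. The estimated step is a number 8 percentage points lower from compound 2 to compound 4 (within the scatter), which is expected to stay within the scatter. For compound 4 the expected value is 92%, with an estimated range of 75% to 100%.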

Compound 4, percent of the compound remaining: 81%
For compound 4 the middle estimate is 11 percentage points above the measured one; the measured number falls inside the stated range.
By their numbers in this assay, from the lowest: compounds 3 and 4 (each within the scatter of the next); then compounds 1 and 2 (each within the scatter of the next).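

In this assay, the change on the amine chain of compound 2 gives a number 19 percentage points lower from compound 2 to compound 4 (beyond the scatter). The earlier fall beyond the scatter came with cyclopentyl, a group that brings a ring, whereas trifluoromethyl brings none, so among these compounds a ring on the amine chain is not needed for a fall of this kind. Nothing measured here explains why the number falls.

The compounds shown leave open whether a difluoromethyl group or a single fluorine at the same place would lower the number as far as trifluoromethyl does. They also leave open how a nitrile or a hydroxyl group there would read, and whether a longer fluorinated chain on the amine nitrogen would lower the number further.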